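A few compounds are considered here, and "the series" means these few. Any claim that something is new, unique, unknown or untested is made for them only; others in the source may bear on it.

Compound 1, `COc1ccc(C2=NN(c3ccccc3)C(c3ccc(C)cc3)C2S(=O)(=O)CC2=NCCO2)cc1`, in a functional assay, read by Griess assay, with a stated time of 150 min, tested at 50 ug/mL (on this read-out higher numbers stand for a stronger effect at the one concentration tested and lower numbers for a weaker effect), gives 59.1%.
Compound 2, `O=S(=O)(CC1=NCCO1)c1n[nH]cc1-c1ccc(Cl)cc1`, in this assay is reported as "not active" (no number reported).
Compound 3, `COc1ccc(C2=NN(c3ccccc3)C(c3ccc(C)cc3)C2S(=O)(=O)CC2=NCCS2)cc1`, in this assay gives 39.4%.

Compound 3 differs from compound 1 by a single change, (a group of 5 heavy atoms (3 carbon, 1 nitrogen, 1 sulfur; one five-membered non-aromatic ring with 2 hetero atoms) in place of a group of 5 heavy atoms (3 carbon, 1 nitrogen, 1 oxygen; one five-membered non-aromatic ring with 2 hetero atoms), on a saturated chain carbon bound to a sulfonyl sulfur). The step it made is a number 19.7 percentage points lower from compound 1 to compound 3 (beyond the scatter). Compound 2 stands on a different core, and the difference between the two cores is not broken down here; compound 2 carries no single number in this assay, only a report of no activity.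

Compound 4, `O=S(=O)(CC1=NCCS1)c1n[nH]cc1-c1ccc(Cl)cc1`, is not yet measured. It differs from compound 2 by a group of 5 heavy atoms (3 carbon, 1 nitrogen, 1 sulfur; one five-membered non-aromatic ring with 2 hetero atoms) in place of a group of 5 heavy atoms (3 carbon, 1 nitrogen, 1 oxygen; one five-membered non-aromatic ring with 2 hetero atoms), on a saturated chain carbon bound to a sulfonyl sulfur. The place of this change is the same as in the pair of compound 1 and compound 3, so it is the same change, now made on the core of compound 2. On the core of compound 1 the change lowered the read-out, as the step of a number 19.7 percentage points lower from compound 1 to compound 3 (beyond the scatter) shows. Compound 2 itself is reported as "not active" (no number reported), so there is no starting number from which a step of that size could be taken. Compound 4 is therefore expected to give about 5%, estimated to fall between 0% and 20%, and a report of no activity with no number is thought the most likely outcome.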

Compound 4, a percentage reported as activity, at one concentration (the size of the read-out at that concentration, not a potency): "not active" (no number reported)
No number was reported for compound 4; the estimate stays without a comparison.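

In this assay compound 2 and compound 4 are both reported as not active with no number, and no step can be read between them. The compounds shown leave open whether the change on a saturated chain carbon bound to a sulfonyl sulfur has any measurable size on this core. No measurement shown bears on this result.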